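Aryloxy variation on the shared core: compound 3

A few compounds are considered here, and "the series" means these few. Any claim that something is new, unique, unknown or untested is made for them only; others in the source may bear on it.

Measured so far:
compound 1 `O=C(O)CC/C=C\CC1COC(c2cccc3ccccc23)OC1c1cccnc1` — 40 nM
compound 2 `Cc1ccc(C#N)c(OC(C)(C)C2OCC(C/C=C\CCC(=O)O)C(c3cccnc3)O2)c1` — 50 nM

In an assay for inhibition of Thromboxane-A synthase (Homo sapiens), using microsomes (a higher number here means a weaker inhibitor, a lower number a stronger inhibitor), compound 1 gives 40 nM and compound 2 gives 50 nM. Compound 2 carries the higher of the two numbers, but its gap to compound 1 is within the scatter, so the two compounds cannot be ordered against each other. They also differ in more than one place, so no single-point step can be read from them.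

Compound 3 `CC(C)(Oc1ccc(F)cc1[N+](=O)[O-])C1OCC(C/C=C\CCC(=O)O)C(c2cccnc2)O1` departs from compound 2 by one change: 4-fluoro-2-nitrophenyl in place of 2-cyano-5-methylphenyl on an oxygen on a saturated carbon. For the measured compounds named here, no measured pair shows what this exchange does, so the size of the step in this assay is open. With the aryloxy group of compound 2 already near the number of compound 1, the expectation is a step no larger than the scatter, in no fixed direction, giving an estimated 1.2-fold higher number from compound 2 to compound 3 (0.08 log units; within the scatter).

Compound 3 is therefore expected at 60 nM, with a range from 20 nM to 180 nM.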

Compound 3, half-maximal inhibitory concentration: 20 nM
For compound 3 the middle estimate is 3.0-fold (0.48 log units) above the measured one; measured number inside the range.
By their numbers in this assay, from the lowest: compounds 3, 1 and 2 (each within the scatter of the next, the first and the last beyond it).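

Within this assay, the exchange of 2-cyano-5-methylphenyl for 4-fluoro-2-nitrophenyl on an oxygen on a saturated carbon gives a 2.5-fold lower number from compound 2 to compound 3 (0.40 log units; beyond the scatter). For the compounds shown here, this is the first single-change step, and it shows that the aryl group at this place can shift the number beyond the scatter while the rest of the molecule stays fixed. No measurement shown here accounts for the size or direction of this step.

The two aryl groups differ in both of their substituents, so the compounds shown cannot assign the step to the fluorine, the nitro group or the loss of the nitrile and methyl groups. Also open, going by these compounds, is how a simple unsubstituted phenyl or a 4-fluorophenyl would read at this place on the shared core.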